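A few compounds are considered here, and "the series" means these few. Any claim that something is new, unique, unknown or untested is made for them only; others in the source may bear on it.

In a functional assay on MOLT-4 cells (Homo sapiens), read by MTT assay, with a stated time of 72 h (a lower number here means a stronger inhibitor, a higher number a weaker inhibitor), compound 2 `CCN(CC)C(=O)NCCCC(C)Nc1cc(OC)cc2cccnc12` gives 155000 nM, the higher of the two numbers shown. Compound 3 `COc1cc(NC(C)CCCNC(=O)N(C2CCCCC2)C2CCCCC2)c2ncccc2c1` gives 36000 nM, a lower number by a margin beyond the usual scatter. Compound 1 `COc1cc(NC(C)CCCNC(=O)NC(c2ccccc2)c2ccccc2)c2ncccc2c1` reaches only an assay limit at >= 500000 nM; this is the limit of >= 500000 nM in this assay, at which 1 of the 3 values shown sits. Compound 4 `COc1cc(NC(C)CCCNC(=O)NCC2CCCCC2)c2ncccc2c1` is not yet measured in this assay; it differs from compound 2 in one place: (cyclohexylmethyl)amino in place of diethylamino on a carbonyl carbon. Going by the values given here, no measured pair shows this exact change, so the expectation rests on the values of compound 2 and compound 3 alone. A modest step toward a lower number is expected, a 2.6-fold lower number from compound 2 to compound 4 (0.41 log units; beyond the scatter). Compound 4 is accordingly estimated at 60000 nM, with a range from 20000 nM to 250000 nM.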

Compound 4, half-maximal inhibitory concentration: 53000 nM
Compound 4: the middle estimate sits 1.1-fold (0.05 log units) above what was measured; measured number inside the range.
By their numbers in this assay, from the lowest: compounds 3 and 4 (each within the scatter of the next); then compound 2. At a limit, above all of these: compound 1.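

In this assay, going by these compounds alone, the pair gives the only measured step at this position, on a carbonyl carbon whose other neighbour is an amide-type nitrogen: (cyclohexylmethyl)amino in place of diethylamino gives a 2.9-fold lower number from compound 2 to compound 4 (0.47 log units; beyond the scatter). The position therefore accepts a group with more heavy atoms, a six-membered carbon ring and a hydrogen-bond donor with a modest gain. Nothing measured here gives a cause for this step. This single pair cannot separate the effect of the ring from that of the donor. As far as these compounds go, whether a benzylamino group or an amine-bearing chain at this position would give a lower number remains open.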